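Removing one methyl from compound 3: expected growth inhibition

The source may hold more compounds than are shown below. What is called first, only, known or untested is meant among the compounds shown, and "the series" means these compounds.

Compound 3 `CCOC(=O)C(C)(C)ON1C(=O)c2ccccc2C1=O` stands at the bottom of the three measured numbers: in a functional assay on the whole organism for inhibition, with Lepidium sativum as the target, tested at 1 ppm (a higher number here means more inhibition of growth at the concentration tested, a lower number less inhibition of growth), compound 3 gives 0%. Compound 1 `COC(=O)C(C)ON1C(=O)c2ccccc2C1=O` gives 64% in this assay, and compound 2 `CC(C)OC(=O)C(C)ON1C(=O)c2ccccc2C1=O` gives 51%; the gap from compound 3 to either of them lies beyond the scatter. Among the measured compounds shown here, the single measured step, a number 13 percentage points lower from compound 1 to compound 2 (beyond the scatter), concerns the ester end of the chain and not the carbon that carries the change considered here. Compound 4 `CCOC(=O)C(C)ON1C(=O)c2ccccc2C1=O` differs from compound 3 by hydrogen in place of methyl on a saturated chain carbon bound to a carbonyl carbon, an oxygen on an unsaturated carbon and a saturated chain carbon. For the measured compounds named here, no measured step covers this change directly. What bears on it is the contrast between compound 3 and compounds 1 and 2: both of those carry a single methyl on that chain carbon and sit far above compound 3, while compound 3 carries two methyls there and shows no inhibition. Compound 4 carries a single methyl and an ethyl ester, which in chain length lies between the esters of compound 1 and compound 2, so its value is expected near theirs. The step from compound 3 is therefore expected to be a large rise, a number 56 percentage points higher from compound 3 to compound 4 (beyond the scatter). For compound 4 the estimate in this assay is 56%, with a range from 35% to 72%.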

Compound 4, percent growth inhibition at one concentration: 68%
Estimate against measurement, compound 4: 12 percentage points below; low and high end bracket the measured number.
By their numbers in this assay, from the lowest: compound 3; then compound 2; then compounds 1 and 4 (each within the scatter of the next).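

In this assay, hydrogen in place of methyl on a saturated chain carbon bound to a carbonyl carbon, an oxygen on an unsaturated carbon and a saturated chain carbon gives a number 68 percentage points higher from compound 3 to compound 4 (beyond the scatter) and now stands as a single change with the ethyl ester held fixed, so this methyl alone separates no inhibition from strong inhibition. The ester end also reads more finely: the ethyl ester against the isopropyl ester gives a number 17 percentage points higher from compound 2 to compound 4 (beyond the scatter) while the ethyl ester against the methyl ester gives a number 4 percentage points higher from compound 1 to compound 4 (within the scatter) and thus only the isopropyl ester stands apart, by a far smaller step than the one at the chain carbon. Nothing at hand explains why the extra methyl on the chain carbon has this effect.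

Among the compounds shown here, how an ethyl group or a longer chain on that same chain carbon would read remains open, as the series holds only hydrogen and methyl there beyond the single methyl common to compounds 1, 2 and 4. A carboxylic acid or an amide at the ester end also lies outside these compounds, so the reading of that end rests on three alkyl esters.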